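From Carbamoyl to Oxetan-3-yl: Expected Stability of Compound 4

The compounds below may be only part of what the source reports. "The series", "measured", "known", "first", "only" and "open" are said of these compounds alone.

Compound 1, `NCCCCN(C[C@@H]1Cc2nccnc2CN1)[C@H]1CCCc2cccnc21`, in an ADME assay on microsomes from liver (Mus musculus) for metabolic stability, using NADPH, with a stated time of 10 min (a lower number here means that less of the compound is left, a higher number that more of the compound is left), gives 73%.
Compound 2, `CN(C[C@@H]1Cc2ncccc2CN1)[C@H]1CCCc2cccnc21`, in this assay gives 0%.
Compound 3, `NC(=O)NCCCCN(C[C@H]1Cc2ncccc2CN1)[C@H]1CCCc2cccnc21`, in this assay gives 32%.

Among these three, compound 3 holds the middle place: its number is beyond the scatter above that of compound 2 and beyond the scatter below that of compound 1. The unmeasured compound 4, `c1cnc2c(c1)CN[C@@H](CN(CCCCNC1COC1)[C@H]1CCCc3cccnc31)C2`, differs from compound 3 in one place: oxetan-3-yl in place of carbamoyl on an amine nitrogen. The chain on the same amine nitrogen is kept; only the group at its end changes, a carbamoyl leaving and an oxetan-3-yl entering.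

For the measured compounds named here, no measured pair shows this exact exchange, so the direction of the step in this assay cannot be read from the data. The three measured numbers span a wide range with small changes at that chain end, so a step of moderate size in either direction would not be surprising. Compound 4 is estimated at 35%, within a range from 10% to 65%. The step from compound 3 is expected to be a number 3 percentage points higher from compound 3 to compound 4 (within the scatter).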

Compound 4, percent of the compound remaining: 41%
Beside the measured number, compound 4's estimate is 6 percentage points below it; measured number inside the range.
By their numbers in this assay, from the lowest: compound 2; then compounds 3 and 4 (each within the scatter of the next); then compound 1.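

In this assay, for the compounds shown here, the step is a number 9 percentage points higher from compound 3 to compound 4 (within the scatter) when oxetan-3-yl replaces carbamoyl on an amine nitrogen at the end of the chain, the first direct comparison at this position. The exchange removes a hydrogen-bond donor and a double bond outside aromatic rings and brings in a four-membered non-aromatic ring, yet this read-out does not separate the two compounds. Nothing measured here offers an explanation for this result.

On these data alone, it remains open whether a cyclobutyl group, with carbon in place of the ring oxygen, or an acetyl group would fall in the same range at this position. The compounds shown also do not tell whether this exchange would give a similar result on a different core or with a longer chain.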